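Bromo in place of methoxy on compound 2

A few compounds are considered here, and "the series" means these few. Any claim that something is new, unique, unknown or untested is made for them only; others in the source may bear on it.

Measured in a functional assay on MCF7 cells (Homo sapiens) for inhibition, read by MTT assay, with a stated time of 24 h; a higher number here means a weaker inhibitor of growth, a lower number a stronger inhibitor of growth
Compound 1 `Cn1cc(-c2nc3ccccc3n2C(=O)c2ccccc2)c2ccccc21` gives 43700 nM
Compound 2 `COc1ccccc1C(=O)n1c(-c2cn(C)c3ccccc23)nc2ccccc21` gives 32100 nM
Compound 3 `COc1ccc(C(=O)n2c(-c3cn(C)c4ccccc34)nc3ccccc32)cc1OC` gives 10200 nM

Compound 2 holds the second highest of these three numbers. Compound 4 `Cn1cc(-c2nc3ccccc3n2C(=O)c2ccccc2Br)c2ccccc21` has not been measured. Among the measured compounds shown here, its one change bromo in place of methoxy on an aromatic carbon puts bromo in place of methoxy on an aromatic carbon. The closest evidence is the step that put methoxy in place of hydrogen, a 1.4-fold lower number from compound 1 to compound 2 (0.13 log units; within the scatter) and it was small. The larger 3.1-fold lower number from compound 2 to compound 3 (0.50 log units; beyond the scatter) came with 3,4-dimethoxyphenyl in place of 2-methoxyphenyl, a different change. No step beyond the scatter is therefore expected in this assay in either direction. The estimated step is a 1.1-fold lower number from compound 2 to compound 4 (0.03 log units; within the scatter) for this swap. The estimate for compound 4 is 30000 nM with an expected range of 13000 nM to 65000 nM for the coming measurement.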

Compound 4, concentration for 50% growth inhibition: 70100 nM
Estimate against measurement, compound 4: 2.3-fold (0.37 log units) below; the measured number lies above the stated range.
By their numbers in this assay, from the lowest: compound 3; then compounds 2, 1 and 4 (each within the scatter of the next, the first and the last beyond it).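

In this assay this position does tell two groups apart, with a 2.2-fold higher number from compound 2 to compound 4 (0.34 log units; beyond the scatter) when bromo replaces methoxy, so the two are not interchangeable here. Set against hydrogen, bromo gives a 1.6-fold higher number from compound 1 to compound 4 (0.21 log units; within the scatter) and cannot be told from it, just as methoxy could not. The 2-bromophenyl in place of 3,4-dimethoxyphenyl gives a 6.9-fold higher number from compound 3 to compound 4 (0.84 log units; beyond the scatter) as the largest step in this set. From the compounds shown here alone, whether an amine or a carboxylic acid at this place, or bromo on another carbon of the ring, would fit this picture stays open. Nothing shown gives a reason for these steps.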